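Swapping the Thiophene Ring for a Methylpyrazole

The source may report more compounds than this note shows. Statements on the series, on what has been measured and on what is new or still open speak of the compounds shown alone.

Of the compounds shown here, two have been measured so far. Compound 1 `O=C1NCCC12CCN(c1c(Cl)cncc1-c1cc[nH]c1)CC2` gives 1050 nM in a functional assay on MV4-11 cells (Homo sapiens) for inhibition, read by resazurin assay, with a stated time of 72 h (on this read-out higher numbers stand for weaker inhibition of growth and lower numbers for stronger inhibition of growth), and compound 2 `CC(=O)c1ccc(-c2cncc(Cl)c2N2CCC3(CCNC3=O)CC2)s1` gives 1440 nM in this assay, the larger of the two numbers, though the gap is small: a 1.4-fold higher number from compound 1 to compound 2 (0.14 log units; within the scatter). That step exchanged a five-membered aromatic ring on the same aromatic carbon of the shared core. Compound 3 `Cn1cc(-c2cncc(Cl)c2N2CCC3(CCNC3=O)CC2)cn1` differs from compound 2 by 1-methyl-1H-pyrazol-4-yl in place of 5-acetylthiophen-2-yl on an aromatic carbon. Because a 1.4-fold higher number from compound 1 to compound 2 (0.14 log units; within the scatter) stayed within the scatter, only a small step is expected for compound 3 as well, a 1.3-fold lower number from compound 2 to compound 3 (0.12 log units; within the scatter), leaning slightly toward compound 1. Compound 3 is therefore estimated at 1100 nM, with a likely range from 500 nM to 2500 nM.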

Compound 3, concentration for 50% growth inhibition: 5530 nM
Compound 3: middle estimate off by 5.0-fold (0.70 log units), on the low side; the whole stated range lies below it.
By their numbers in this assay, from the lowest: compounds 1 and 2 (each within the scatter of the next); then compound 3.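

This aromatic carbon does respond to the group it carries: in this assay, 1-methyl-1H-pyrazol-4-yl gives a 3.8-fold higher number from compound 2 to compound 3 (0.58 log units; beyond the scatter) and a 5.3-fold higher number from compound 1 to compound 3 (0.72 log units; beyond the scatter) and so weaker inhibition of growth, unlike the earlier exchange of 1H-pyrrol-3-yl for 5-acetylthiophen-2-yl. The count of hydrogen-bond acceptors does not separate compound 2 from compound 3, as the leaving and entering groups have the same count. No measured evidence here accounts for the rise in the number.

From the compounds shown here alone, whether the methyl on the pyrazole contributes to the step remains open. Going by these compounds, how an amine or a carboxylic acid would read on this aromatic carbon also remains open.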